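A few compounds are considered here, and "the series" means these few. Any claim that something is new, unique, unknown or untested is made for them only; others in the source may bear on it.

Measured compounds:
compound 1 `O=C(Nc1cccc(C(F)(F)F)c1)c1cc(Cl)ccc1O` — 537 nM
compound 2 `O=C(Nc1cc(Cl)cc(Cl)c1)c1cc(Cl)ccc1O` — 712 nM

In an assay on cells for antagonist activity at P2X purinoceptor 4 (Homo sapiens), read by fluorescence and calcium flux, with a stated time of 30 min (on this read-out higher numbers stand for weaker inhibition and lower numbers for stronger inhibition), compound 2 gives 712 nM, the higher of the two numbers, while compound 1 in this assay gives 537 nM; the two lie within the scatter of one another, so no order between them is claimed.

Compound 3 `O=C(Nc1cccc(Cl)c1)c1cc(Cl)ccc1O` differs from compound 2 by hydrogen in place of chloro on an aromatic carbon. Going by the values given here, no measured pair shows this change, so its size is unknown; the expectation is a step in this assay that is small, if anything toward a higher number, and plausibly within the scatter.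

Compound 3 is expected at 1000 nM, with a range from 400 nM to 2500 nM. The expected step is a 1.4-fold higher number from compound 2 to compound 3 (0.15 log units; within the scatter).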

Compound 3, half-maximal inhibitory concentration: 135 nM
The estimate for compound 3 lay 7.4-fold (0.87 log units) above the measured number; measured number outside the range, below it.
By their numbers in this assay, from the lowest: compound 3; then compounds 1 and 2 (each within the scatter of the next).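

In this assay, hydrogen in place of chloro on this aromatic carbon gives a clear drop in the number (a 5.3-fold lower number from compound 2 to compound 3 (0.72 log units; beyond the scatter)), so a second substituent here is not needed for inhibition in this pair. Chloro in place of trifluoromethyl also lowers the number (a 4.0-fold lower number from compound 1 to compound 3 (0.60 log units; beyond the scatter)), a sensitivity to the group at that site that compound 1 and compound 2 alone, within the scatter of each other, did not show. Nothing measured here accounts for either step.

From the compounds shown here alone, whether a nitrile, a methoxy group or an amine at these sites would keep the lower number stays open. So does whether the two steps hold when the core changes elsewhere.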